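The source may hold more compounds than are shown below. What is called first, only, known or untested is meant among the compounds shown, and "the series" means these compounds.

In an assay on brain for inhibition of Fatty-acid amide hydrolase 1 (Rattus norvegicus), read by scintillation counting, with a stated time of 10 min (a higher number here means a weaker inhibitor, a lower number a stronger inhibitor), three compounds have been measured so far:

Compound 1, `CC(C)Cc1ccc(C(C)C(=O)NCc2ccc(Cl)cc2)cc1`, gives 27000 nM.
Compound 2, `CC(C)Cc1ccc(C(C)C(=O)NCc2ccc(Cl)cc2Cl)cc1`, gives 21000 nM.
Compound 3, `CC(C)Cc1ccc(C(C)C(=O)N2CCN(c3ccc(Cl)cc3)CC2)cc1`, gives 1700 nM.

Compounds 1 and 2 share one core, and compound 3 rests on another; the difference between the two cores is not broken down here. What the values show is that compound 3 gives a lower number in this assay than either compound 1 or compound 2, and both of those gaps lie beyond the scatter of repeated measurement.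

From compound 1 to compound 2 the change is chloro in place of hydrogen on an aromatic carbon and it produced a 1.3-fold lower number from compound 1 to compound 2 (0.11 log units; within the scatter), a step that stays within the scatter.

Compound 4, `CC(C)Cc1ccc(C(C)C(=O)N2CCN(c3ccc(Cl)c(Cl)c3)CC2)cc1`, has not yet been measured in this assay. It stands to compound 3 as compound 2 stands to compound 1: the change is chloro in place of hydrogen on an aromatic carbon. Within the data shown here, this is the same kind of change as the one from compound 1 to compound 2, but not the same, since the surroundings of the place differ. In compound 2 the entering chloro sits ortho to a large group and meta to a chloro group, while in compound 4 it sits ortho to a chloro group and meta to a large group.

Among the measured compounds shown here, the only comparable step, a 1.3-fold lower number from compound 1 to compound 2 (0.11 log units; within the scatter), stayed within the scatter, and on that single precedent compound 4 is expected to give a number close to that of compound 3. The expected step is a 1.3-fold lower number from compound 3 to compound 4 (0.12 log units; within the scatter). For compound 4 the estimate in this assay is 1300 nM, with a range from 500 nM to 3500 nM.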

Compound 4, half-maximal inhibitory concentration: 16000 nM
Compound 4: middle estimate off by 12-fold (1.09 log units), on the low side, outside the stated range (above it).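

In this assay, the added chloro on the core of compound 3 gave a 9.4-fold higher number from compound 3 to compound 4 (0.97 log units; beyond the scatter), whereas the same change on the core of compound 1 stayed within the scatter. The change therefore did not carry over from one core to the other with the same size, and the gap between the two steps is larger than repeated measurement would explain: the same change on two cores in this assay, a 1.3-fold lower number (0.11 log units; within the scatter) from compound 1 to compound 2 and a 9.4-fold higher number (0.97 log units; beyond the scatter) from compound 3 to compound 4, 12-fold (1.08 log units) apart, beyond the scatter of two such steps. This comparison rests on a single pair on each core, and the entering chloro in compound 4 sits ortho to a chloro group, so the data show that the outcome of this change is not transferable between these two pairs, but they do not separate the role of the core from the role of the chloro's surroundings, and they give no reason for the difference.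

The compounds shown leave open whether other groups at the same place on the 4-chlorophenyl ring of compound 3, such as fluoro, methyl or methoxy, would follow the chloro in compound 4. They also leave open whether a 3,4-difluorophenyl group would behave like the 3,4-dichlorophenyl group on this core.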